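A few compounds are considered here, and "the series" means these few. Any claim that something is new, unique, unknown or untested is made for them only; others in the source may bear on it.

Compound 1 `C=C1C(=O)O[C@@H](c2ccccc2)[C@H]1C` gives 41% in a functional assay on BXPC-3 cells (Homo sapiens) for cytotoxicity, read by MTT assay, with a stated time of 72 h, tested at 10 uM; on this read-out lower numbers stand for a stronger effect and higher numbers for a weaker effect at the one concentration tested.
Compound 2 `C=C1C(=O)O[C@@H](c2ccc(OC)cc2)[C@H]1C` gives 13% in this assay.
Compound 3 `C=C1C(=O)O[C@H](c2ccccc2)[C@H]1c1ccccc1` gives 1% in this assay.

The change from compound 1 to compound 2, (methoxy in place of hydrogen on an aromatic carbon), produced a number 28 percentage points lower from compound 1 to compound 2 (beyond the scatter). Compound 3 stands lowest of the three, and the difference between its core and the core of compound 1 is not broken down here. Compound 4 `C=C1C(=O)O[C@H](c2ccc(OC)cc2)[C@H]1c1ccccc1` has not yet been measured. It differs from compound 3 by methoxy in place of hydrogen on an aromatic carbon; the surroundings of the place are not identical, since here the methoxy is para to a large group, so this is the same kind of change rather than the same change. Because compound 3 already sits at 1%, little room remains downward, so the expected step is a number 2 percentage points higher from compound 3 to compound 4 (within the scatter), smaller than the earlier one. Compound 4 is estimated at 3%, expected between 0% and 12%.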

Compound 4, a percentage reported as activity, at one concentration (the size of the read-out at that concentration, not a potency): 0%
The estimate for compound 4 lay 3 percentage points above the measured number; the range from low to high includes it.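

On the core of compound 3, methoxy in place of hydrogen gave a number 1 percentage points lower from compound 3 to compound 4 (within the scatter). Set beside the earlier step, this shows that the size of the change did not carry over from one core to the other in this assay: the same change on two cores in this assay, a number 28 percentage points lower (beyond the scatter) from compound 1 to compound 2 and a number 1 percentage points lower (within the scatter) from compound 3 to compound 4, 27 percentage points apart, beyond the scatter of two such steps

It does not show that methoxy has no effect on the second core, since compound 3 gives 1%, which leaves almost no room for a lower number to appear.

The compounds shown carry only hydrogen or methoxy at this place on the aromatic ring, so an amine, a carboxylic acid or a longer chain such as butoxy remains open. Going by these compounds, how methoxy behaves on any third core also remains open.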